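A few compounds are considered here, and "the series" means these few. Any claim that something is new, unique, unknown or untested is made for them only; others in the source may bear on it.

Of the compounds shown here, three built on one shared core have been tested in a functional assay on the whole organism with Mus musculus as the target, with a stated time of 90 min, at a dose of 25 umol/kg by the oral route; a higher number here means a stronger effect of the compound at the dose given, a lower number a weaker effect. Compound 1 `C[C@H](NC(=O)CN(c1nc(Cl)nc2c1ncn2C1CCCCO1)C1CC1)C(=O)OCc1ccccc1` gives 32.1%. Compound 2 `N=C(N)NCCC[C@H](NC(=O)CN(c1nc(Cl)nc2c1ncn2C1CCCCO1)C1CC1)C(=O)OCc1ccccc1` gives 61.6%. Compound 3 `CC(C)C[C@H](NC(=O)CN(c1nc(Cl)nc2c1ncn2C1CCCCO1)C1CC1)C(=O)OCc1ccccc1` gives 28.2%, the lowest of the three numbers; its gap to compound 1 lies within the scatter, whereas compound 2 stands clearly higher, as the step of a number 33.4 percentage points lower from compound 2 to compound 3 (beyond the scatter) shows. The remaining measured steps are a number 29.5 percentage points higher from compound 1 to compound 2 (beyond the scatter) and a number 3.9 percentage points lower from compound 1 to compound 3 (within the scatter).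

Compound 4 `CC(C)[C@H](NC(=O)CN(c1nc(Cl)nc2c1ncn2C1CCCCO1)C1CC1)C(=O)OCc1ccccc1` differs from compound 3 in a single place: isopropyl in place of isobutyl on a saturated chain carbon bound to an amide-type nitrogen and a carbonyl carbon. Of the measured steps, only one concerns a carbon-only side group on this stretch of the chain, namely a number 3.9 percentage points lower from compound 1 to compound 3 (within the scatter), and that step stayed within the scatter. The two larger steps, a number 29.5 percentage points higher from compound 1 to compound 2 (beyond the scatter) and a number 33.4 percentage points lower from compound 2 to compound 3 (beyond the scatter), both arise from the group containing three nitrogen atoms and so say little about exchanging one small carbon-only group for another. Because a number 3.9 percentage points lower from compound 1 to compound 3 (within the scatter) was so small, the expected step of a number 0.8 percentage points higher from compound 3 to compound 4 (within the scatter) is one that does not go beyond the scatter in either direction. Compound 4 is therefore expected to give about 29%, with a likely range from 17% to 41%.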

Compound 4, a percentage reported as activity, at one dose (the size of the read-out at that dose, not a potency): 30.1%
For compound 4 the middle estimate is 1.1 percentage points below the measured one; the range from low to high includes it.
By their numbers in this assay, from the lowest: compounds 3, 4 and 1 (each within the scatter of the next); then compound 2.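

In this assay, isopropyl in place of isobutyl on the saturated chain carbon bound to an amide-type nitrogen and a carbonyl carbon gives a number 1.9 percentage points higher from compound 3 to compound 4 (within the scatter), and isopropyl in place of methyl gives a number 2 percentage points lower from compound 1 to compound 4 (within the scatter), so this read-out cannot tell the three carbon-only side groups, methyl, isopropyl and isobutyl, apart. The group with three nitrogen atoms in compound 2 is the only one that stands apart, as a number 31.5 percentage points lower from compound 2 to compound 4 (beyond the scatter) shows, and a third carbon-only compound now supports that contrast. Nothing available explains why the numbers fall this way.

From the compounds shown here alone, it remains open whether the nitrogen atoms or the length of the side chain set compound 2 apart, a question that a plain amine on a similar chain, a carboxylic acid or a longer all-carbon chain could help to separate. It is also open whether a benzyl group on this carbon would stay level with the small carbon-only groups, and a read-out at a single dose gives no potency for any of these compounds.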